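A few compounds are considered here, and "the series" means these few. Any claim that something is new, unique, unknown or untested is made for them only; others in the source may bear on it.

Compound 1 `CCn1c(C(=O)N(CCC#N)CCC#N)ccc1C(CC)(CC)c1ccc(OCCC(O)(CC)CC)c(C)c1` gives > 50000 nM in a functional assay on Caco-2 cells (Homo sapiens) for antiproliferative activity, read by MTT assay, with a stated time of 48 h (a higher number here means a weaker inhibitor, a lower number a stronger inhibitor), which is a limit of the assay.
Compound 2 `C#CCCOC(=O)c1ccc(C(CC)(CC)c2ccc(OCCC(O)(CC)CC)c(C)c2)n1CC` gives > 50000 nM in this assay, also a limit.
Compound 3 `CCOC(=O)CN(C)C(=O)c1ccc(C(CC)(CC)c2ccc(OCCC(O)(CC)CC)c(C)c2)n1CC` gives 30300 nM in this assay.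

Compound 2 therefore stands at the limit of > 50000 nM in this assay, at which 2 of the 3 values shown sit, and so gives no number of its own. Compound 4 `CCC(C)C(CO)NC(=O)c1ccc(C(CC)(CC)c2ccc(OCCC(O)(CC)CC)c(C)c2)n1CC` differs from compound 2 by (1-(hydroxymethyl)-2-methylbutyl)amino in place of (but-3-yn-1-yl)oxy on a carbonyl carbon. Among the compounds with values here, the only measured step that bears on this change is the one from an ester to an amide on the same carbonyl carbon, an at least 1.6-fold lower number from compound 2 to compound 3 (0.21 log units; that floor lies within the scatter), and its floor lies within the scatter, so it shows no clear movement. For compound 4 the expected step from compound 2 is therefore small, an at least 1.2-fold lower number from compound 2 to compound 4 (0.09 log units; that floor lies within the scatter), toward a number near or just under the limit. Compound 4 is estimated at 40000 nM, with a range from 15000 nM to 100000 nM.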

Compound 4, half-maximal inhibitory concentration: > 50000 nM
Compound 4: a limit, no number (the forecaster's own chance of this, stated with the estimate: 45%); at least 1.2-fold (0.09 log units) between middle value and limit.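

In this assay, the value of compound 4 is a limit, so the (1-(hydroxymethyl)-2-methylbutyl)amino group gives no readable number on this carbonyl carbon: the limit of > 50000 nM in this assay, at which 3 of the 4 values shown sit. Set against the other amide with a number, the change is an at least 1.6-fold higher number from compound 3 to compound 4 (0.21 log units; that floor lies within the scatter), so no clear movement is shown. The steps from compound 1 and compound 2 to compound 4 cannot be read, since both ends are limits. Still open, as far as these compounds go, is whether a carboxylic acid or a small methylamino group on this carbonyl carbon would give a number under the limit.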